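The source may report more compounds than this note shows. Statements on the series, on what has been measured and on what is new or still open speak of the compounds shown alone.

Of the compounds shown here, three built on one shared core have been tested in an ADME assay on Vero cells (Chlorocebus sabaeus) for cytotoxicity, read by MTT assay, with a stated time of 72 h; a lower number here means that less compound is tolerated, a higher number that more compound is tolerated. Compound 1 `CNC1=C([N+](=O)[O-])C(c2ccc(N3CCN(c4ccnc5cc(Cl)ccc45)CC3)cc2)c2ccccc2O1` carries hydrogen at both positions varied here. In this assay compound 1 gives > 200000 nM, which is a limit of the assay and not a number. Compound 2 `CNC1=C([N+](=O)[O-])C(c2ccc(N3CCN(c4ccnc5cc(Cl)ccc45)CC3)cc2)c2cc(Br)ccc2O1` has bromo in place of hydrogen on an aromatic carbon, and in this assay compound 2 gives 88600 nM. Compound 3 `CCOc1cccc2c1OC(NC)=C([N+](=O)[O-])C2c1ccc(N2CCN(c3ccnc4cc(Cl)ccc34)CC2)cc1` has ethoxy in place of hydrogen on an aromatic carbon; in this assay compound 3 gives 40400 nM, the lowest of the two numbers, with compound 2 nearest and beyond the scatter. The measured steps are an at least 2.2-fold lower number from compound 1 to compound 2 (0.35 log units; beyond the scatter) and an at least 4.9-fold lower number from compound 1 to compound 3 (0.69 log units; beyond the scatter).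

Compound 4 `CNC1=C([N+](=O)[O-])C(c2ccc(N3CCN(c4ccnc5cc(Cl)ccc45)CC3)cc2)c2cccc(OC)c2O1` differs from compound 3 by hydrogen in place of methyl on a saturated chain carbon bound to an oxygen on an aromatic ring, that is, ethoxy to methoxy. The step of an at least 4.9-fold lower number from compound 1 to compound 3 (0.69 log units; beyond the scatter) shows that the ethoxy group lowered the number; trimming it by one carbon is expected to move the number only slightly, if at all, so the expected step is a 1.5-fold higher number from compound 3 to compound 4 (0.17 log units; within the scatter). Compound 4 is therefore estimated at 60000 nM, within a range from 25000 nM to 150000 nM.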

Compound 4, half-maximal cytotoxic concentration: 21800 nM
Estimate against measurement, compound 4: 2.8-fold (0.44 log units) above; measured number outside the range, below it.
By their numbers in this assay, from the lowest: compounds 4 and 3 (each within the scatter of the next); then compound 2. At a limit, above all of these: compound 1.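

In this assay, the change from ethoxy to methoxy gives a 1.9-fold lower number from compound 3 to compound 4 (0.27 log units; within the scatter), so the methyl that leaves does not separate compound 3 from compound 4 at this place. Methoxy in place of hydrogen gives an at least 9.1-fold lower number from compound 1 to compound 4 (0.96 log units; beyond the scatter), which shows that the lower number seen with ethoxy is also seen with the shorter group. The exact size of that step cannot be read, because compound 1 stands at a limit of the assay and not at a number: the limit of > 200000 nM in this assay, at which 1 of the 4 values shown sits.

The compounds shown leave open whether a longer chain such as propoxy, or a hydroxyl group in place of methoxy, would stay in the same range as compound 3 and compound 4. They also leave open whether an amine at this place would give a number closer to that of compound 1.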